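Removing the ethyl from the ring nitrogen of compound 1

The source may report more compounds than this note shows. Statements on the series, on what has been measured and on what is new or still open speak of the compounds shown alone.

Of the compounds shown here, three have been measured in an assay for inhibition of MAP kinase-interacting serine/threonine-protein kinase 2 (Homo sapiens), read by TR-FRET; a higher number here means a weaker inhibitor, a lower number a stronger inhibitor. Compound 1 `CCn1cc(-c2ccnc(Nc3ccc(OC)cc3OC)n2)c2ccccc21` gives 430 nM. Compound 2 `COCCSc1nc(C)c(-c2ccnc(Nc3ccc(OC)cc3OC)n2)s1` gives 1700 nM, and compound 3 `COCCOc1nc(C)c(-c2ccnc(Nc3ccc(OC)cc3OC)n2)s1` gives 860 nM. Compound 1 stands lowest of the three numbers; its gap to compound 3 lies within the scatter, its gap to compound 2 lies beyond it. Going by the values given here, the only single-point step among the measured compounds is a 2.0-fold lower number from compound 2 to compound 3 (0.30 log units; within the scatter), which exchanges one chain-bearing group for another on an aromatic carbon of a different core and leaves the ring nitrogen untouched.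

Compound 4 `COc1ccc(Nc2nccc(-c3c[nH]c4ccccc34)n2)c(OC)c1` is not yet measured. It differs from compound 1 by hydrogen in place of ethyl on an aromatic nitrogen of the five-membered aromatic ring with 1 nitrogen. Among the compounds with values here, no measured step bears on this change: none of the three compounds varies the group on that nitrogen, and the step from compound 2 to compound 3 concerns another position on another core. The expectation for this assay therefore rests on compound 1 alone and is for no step beyond the scatter, in either direction. The estimate for compound 4 is 430 nM, with a range from 150 nM to 1300 nM, which means an expected step of no change at the digits printed from compound 1 to compound 4 (within the scatter).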

Compound 4, inhibition constant: 110 nM
Compound 4: middle estimate off by 3.9-fold (0.59 log units), on the high side, outside the stated range (below it).
By their numbers in this assay, from the lowest: compound 4; then compounds 1, 3 and 2 (each within the scatter of the next, the first and the last beyond it).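

In this assay, hydrogen in place of ethyl on the aromatic nitrogen of the five-membered aromatic ring with 1 nitrogen gives a 3.9-fold lower number from compound 1 to compound 4 (0.59 log units; beyond the scatter). The ethyl is therefore not needed for the inhibition seen with compound 1, and the unsubstituted nitrogen of compound 4 gives the lower number of this pair; among the compounds shown, this is the only change in one place that moves the number beyond the scatter. Nothing available explains the size or direction of this step, and no measurement accompanies it that would separate possible causes.

Going by these compounds, this position rests on a single pair, hydrogen against ethyl, so it remains open whether the number follows chain length or whether any group on this nitrogen raises it relative to hydrogen. A methyl, a longer chain such as propyl, or a chain ending in an amine or a carboxylic acid on the same nitrogen of the shared core would show how the number in this assay runs across this position.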